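Growing the ring from cyclobutyl to cyclopentyl

The compounds below may be only part of what the source reports. "The series", "measured", "known", "first", "only" and "open" are said of these compounds alone.

Compound 1 `C1CCC(C(CC2CCCCN2)C2CCCC2)CC1`: 0.317 h
Compound 2 `C1CCC(CC(C2CCCC2)C2CC2)NC1`: 0.05 h
Compound 3 `C1CCC(CC(C2CCCC2)C2CCC2)NC1`: 0.117 h

In an ADME assay on microsomes from liver (Rattus norvegicus, strain Sprague-Dawley) for metabolic stability, read by LC-MS, using NADPH, with a stated time of 45 min, tested at 3 uM (on this read-out lower numbers stand for a shorter-lived compound and higher numbers for a longer-lived compound), compound 3 gives 0.117 h, the second highest of the three numbers. Compound 4 `C1CCC(CC(C2CCCC2)C2CCCC2)NC1` has cyclopentyl in place of cyclobutyl on a saturated chain carbon bound to a saturated chain carbon and a saturated ring carbon.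

Going by the values given here, two measured steps bear on this change. Cyclobutyl in place of cyclopropyl gave a 2.3-fold higher number from compound 2 to compound 3 (0.37 log units; beyond the scatter), and cyclobutyl in place of cyclohexyl gave a 2.7-fold lower number from compound 1 to compound 3 (0.43 log units; beyond the scatter). In these three compounds, the larger ring goes with the higher number, and none goes against this. Cyclopentyl is larger than cyclobutyl and smaller than cyclohexyl, so a small rise is expected in this assay. The expected step is a 1.7-fold higher number from compound 3 to compound 4 (0.23 log units; within the scatter). Compound 4 is estimated at 0.2 h, with an expected range of 0.1 h to 0.38 h.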

Compound 4, half-life: 0.233 h
Compound 4: the middle estimate sits 1.2-fold (0.07 log units) below what was measured, within the range that was stated.
By their numbers in this assay, from the lowest: compound 2; then compounds 3, 4 and 1 (each within the scatter of the next, the first and the last beyond it).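

In this assay cyclopentyl cannot be told apart from cyclobutyl (a 2.0-fold higher number from compound 3 to compound 4 (0.30 log units; within the scatter)) or from cyclohexyl (a 1.4-fold lower number from compound 1 to compound 4 (0.13 log units; within the scatter)). Going by these compounds alone, it stands clear only of cyclopropyl (a 4.7-fold higher number from compound 2 to compound 4 (0.67 log units; beyond the scatter)), so the link between ring size and number rests on the ends of this series, and the single added ring carbon here gives no step that can be read. Nothing shown here accounts for this. Still open, as far as these compounds go, is whether an open chain such as isopropyl or tert-butyl, or a ring holding oxygen such as tetrahydropyranyl, would fit the same order at this carbon.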